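The compounds below may be only part of what the source reports. "The series", "measured", "known", "first", "only" and "open" are said of these compounds alone.

Measured in a functional assay on the whole organism with Oryctolagus cuniculus as the target; on this read-out lower numbers stand for stronger inhibition and higher numbers for weaker inhibition:
- compound 1 `CO/C(O)=C1\C(C)=Nc2ccccc2SC1c1ccccc1C(F)(F)F` gives 12000 nM
- compound 2 `CO/C(O)=C1\C(C)=Nc2ccccc2SC1c1ccc([N+](=O)[O-])cc1` gives 3000 nM
- compound 3 `CO/C(O)=C1\C(C)=Nc2ccccc2SC1c1ccccc1` gives 1700 nM

Two measured steps end at compound 3. One is a 1.8-fold lower number from compound 2 to compound 3 (0.25 log units; within the scatter), with hydrogen in place of nitro. The other is a 7.1-fold lower number from compound 1 to compound 3 (0.85 log units; beyond the scatter), with hydrogen in place of trifluoromethyl. Compound 3 therefore sits with compound 2 at the low end of these numbers, and stands clearly apart only from compound 1.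

Compound 4 `CO/C(O)=C1\C(C)=Nc2ccccc2SC1c1ccc(OC)cc1` has the same core and carries methoxy in place of hydrogen on an aromatic carbon, para to a large group: methoxy in place of hydrogen on an aromatic carbon.

For the measured compounds named here, no methoxy compound has been measured, so the expectation rests on those two steps alone. Neither compound 1 nor compound 2 has a number clearly lower than compound 3, but the two steps differ in size, which leaves the range wide. A small move toward a higher number in this assay is expected, not beyond the scatter. The expected change is a 1.4-fold higher number from compound 3 to compound 4 (0.13 log units; within the scatter). The estimated value for compound 4 is 2300 nM, with an expected range from 900 nM to 6000 nM.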

Compound 4, half-maximal inhibitory concentration: 22000 nM
The estimate for compound 4 lay 9.6-fold (0.98 log units) below the measured number; the whole stated range lies below it.
By their numbers in this assay, from the lowest: compounds 3 and 2 (each within the scatter of the next); then compounds 1 and 4 (each within the scatter of the next).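

In this assay, for the compounds shown here, methoxy on this aromatic carbon, para to a large group, gives a 13-fold higher number from compound 3 to compound 4 (1.11 log units; beyond the scatter) and is the first change at this position to lie beyond the scatter. The replacement of nitro by the same group points the same way, with a 7.3-fold higher number from compound 2 to compound 4 (0.87 log units; beyond the scatter), whereas hydrogen and nitro at this position stay within the scatter of each other, so this position does not tolerate every group equally and the two earlier compounds gave no sign of that. The data offer no measurement that would explain why methoxy parts from hydrogen and nitro here.

Among the compounds shown, methoxy is the only group at this position that stands apart, so it remains open whether a hydroxyl, an ethoxy, a methyl or an amine in the same place would stay close to hydrogen and nitro or move with methoxy. As far as these compounds go, it also remains open whether methoxy on another carbon of the same aromatic ring would give a step of similar size, or whether the step belongs to this position alone.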